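The source may hold more compounds than are shown below. What is called first, only, known or untested is meant among the compounds shown, and "the series" means these compounds.

Measured compounds:
- compound 1 `O=C(/N=C1\NC2(CCCCO2)CCS1)c1ccc(F)cc1`: 8.8 mg/kg; 28 mg/kg; 49 mg/kg (3 entries)
- compound 2 `Cc1ccc(C(=O)/N=C2\NC3(CCCCO3)CCS2)cc1`: 60 mg/kg

The two measured compounds share a core and differ only in the aromatic group attached to the carbonyl carbon. In a functional assay on the whole organism (strain CF-1) with Mus musculus as the target, in the writhing test, with a stated time of 15 min (a higher number here means that more compound is needed for the effect, a lower number that less compound is needed), compound 1 gives 8.8 mg/kg; 28 mg/kg; 49 mg/kg (3 entries). These repeated determinations, (the several entries of compound 1 in this assay, 8.8 mg/kg; 28 mg/kg; 49 mg/kg (3 entries)), spread over a range wider than the usual scatter, so any single determination in this assay carries limited weight. Compound 2 has a single number in this assay, 60 mg/kg, plus one further entry that yields no single number. Going by the values given here, that one number lies close to the higher entries of compound 1 and far from its lowest; no step between the two compounds is established from this.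

Compound 3 `O=C(/N=C1\NC2(CCCCO2)CCS1)c1ccco1` has not yet been measured. It differs from compound 2 by furan-2-yl in place of 4-methylphenyl on a carbonyl carbon. Among the compounds with values here, no measured pair isolates such a change, so the step expected from compound 2 to compound 3 in this assay, a 1.3-fold lower number from compound 2 to compound 3 (0.12 log units; within the scatter), is none beyond the scatter. Compound 3 is therefore estimated at 45 mg/kg, with a range from 15 mg/kg to 140 mg/kg.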

Compound 3, dose for half-maximal effect: 42 mg/kg
Compound 3: middle estimate off by 1.1-fold (0.03 log units), on the high side; measured number inside the range.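

In this assay, furan-2-yl in place of 4-methylphenyl on a carbonyl carbon gives a 1.4-fold lower number from compound 2 to compound 3 (0.15 log units; within the scatter). This pair isolates a change at this place, and it shows that a five-membered aromatic ring with 1 hetero atom can replace a six-membered aromatic ring of carbon only without a step beyond the scatter, even though the entering group also brings a hydrogen-bond acceptor and has fewer heavy atoms. Even so, this single step is a modest basis for a firm reading, as the repeated determinations of compound 1 show a wide spread: the several entries of compound 1 in this assay, 8.8 mg/kg; 28 mg/kg; 49 mg/kg (3 entries).

The compounds shown leave open whether a group of another kind on this carbonyl carbon, such as a cyclohexyl ring, a longer alkyl chain, or a phenyl ring carrying an amine or a carboxylic acid, would give a step beyond the scatter. Going by these compounds, whether furan-2-yl in place of 4-methylphenyl gives a similar step on a different core also remains open.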